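The source may report more compounds than this note shows. Statements on the series, on what has been measured and on what is new or still open speak of the compounds shown alone.

Measured compounds:
Compound 1, `O=C(Nc1ccc(F)cc1)N1N=C(c2ccc(Br)cc2)CC1c1ccc(F)cc1`: > 10000 nM
Compound 2, `CC(C)NC(=O)N1N=C(c2ccc(Br)cc2)CC1c1ccc(F)cc1`: 2360 nM

In an assay on HEK293 cells for inhibition of Voltage-dependent L-type calcium channel subunit alpha-1C (Homo sapiens), read by FLIPR and calcium flux, with a stated time of 3 min (a lower number here means a stronger inhibitor, a higher number a weaker inhibitor), compound 1 gives > 10000 nM, which is a limit of the assay and not a number. In this assay compound 2 gives 2360 nM. Within the data shown here, the one measured step, an at least 4.2-fold lower number from compound 1 to compound 2 (0.62 log units; beyond the scatter), is the only comparison available, and it concerns the substituent on the amide-type nitrogen, not the part of the shared core that changes here. Compound 1 thus stands at the weak end of what has been measured, as the limit of > 10000 nM in this assay, at which 1 of the 2 values shown sits, shows.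

Compound 3, `O=C(Nc1ccc(F)cc1)N1N=C(c2cc[n+]([O-])cc2)CC1c1ccc(F)cc1`, differs from compound 1 at the carbon with a double bond to nitrogen: a group of 7 heavy atoms (5 carbon, 1 nitrogen, 1 oxygen; one six-membered aromatic ring with 1 hetero atom) in place of a group of 7 heavy atoms (6 carbon, 1 bromine; one six-membered aromatic ring of carbon only), on a carbon with a double bond to nitrogen. Among the measured compounds shown here, no measured step touches this position, so the data give no direction for the change. With compound 1 already at the limit, compound 3 is expected to remain in the weak range in this assay as well, and a reading at the limit is considered likely. For compound 3 the expected step is a step that the limit leaves unreadable from compound 1 to compound 3. Compound 3 is estimated at 15000 nM, between 4000 nM and 60000 nM.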

Compound 3, half-maximal inhibitory concentration: > 10000 nM
Compound 3 ended at the assay's limit; the forecaster's own chance of this, stated with the estimate: 70%; the middle value does not contradict the limit.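

No new step can be read from this result: in this assay, compound 1 and compound 3 both sit at a limit of the assay and not at a number, so the step between them cannot be read. The compounds shown leave open what the group entering in compound 3 does to the value when the isopropyl of compound 2 is present.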